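Swapping an isopropyl ester for an ethyl ester

The source may report more compounds than this note shows. Statements on the series, on what has been measured and on what is new or still open speak of the compounds shown alone.

In an ADME assay on a cell-free system (plasma, Macaca mulatta) for metabolic stability, read by LC-MS, with a stated time of 60 min, tested at 10 uM (a lower number here means that less of the compound is left, a higher number that more of the compound is left), compound 1 (`CC(C)C[C@H](N)C(=O)N[C@@H](CCC(=O)C=[N+]=[N-])C(=O)OC(C)C`) reads 1% and lies within the usual scatter of compound 2 (`Cc1oc(=O)oc1COC(=O)N[C@@H](CCC(=O)C=[N+]=[N-])C(=O)OC(C)C`) at 0% while compound 3 (`COC(=O)[C@H](CCC(=O)C=[N+]=[N-])NC(=O)OC(OC(=O)C(C)(C)C)C(C)C`) reads 61% in the same test, well clear of both. Compound 4 (`CCOC(=O)[C@H](CCC(=O)C=[N+]=[N-])NC(=O)[C@@H](N)CC(C)C`) turns the isopropoxycarbonyl of compound 1 into ethoxycarbonyl (hydrogen in place of methyl on a saturated chain carbon bound to an oxygen next to a carbonyl group and a saturated chain carbon), with hydrogen in place of methyl on a saturated chain carbon bound to an oxygen next to a carbonyl group and a saturated chain carbon. Among the measured compounds shown here, compound 3 differs from compound 1 in more than one place, and no measured pair shows this change alone. The expected step of a number 2 percentage points higher from compound 1 to compound 4 (within the scatter) is a small one that stays within the scatter. For compound 4 the estimated value is 3% (range 0% to 15%).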

Compound 4, percent of the compound remaining: 1%
Compound 4: the middle estimate sits 2 percentage points above what was measured, within the range that was stated.
By their numbers in this assay, from the lowest: compounds 2, 1 and 4 (each within the scatter of the next); then compound 3.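

Trimming the isopropyl of the ester to ethyl gives no change at the digits printed from compound 1 to compound 4 (within the scatter) in this assay and is the first single-place change that can be read at this position. With one methyl gone from the saturated chain carbon bound to the ester oxygen, very little of the compound remains in either case, so this change alone does not alter the read-out. No measurement shown explains this result. From the compounds shown here alone, a longer chain, such as butyl, or a carboxylic acid in place of the ester remains open. So does whether this same swap would matter in a compound of which more remains.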